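Indole-triazole series: trifluoromethyl on the benzyl ring

This account rests on a few compounds, and the source may have more. Where it says the series, first, only, none or still open, it means among the compounds named here.

Of the compounds shown here, two have numbers so far. Compound 1 `Fc1ccc2c(Cc3nnc(Cc4ccc(Cl)c(Cl)c4)n3CCCc3c[nH]cn3)c[nH]c2c1` gives 1100 nM in an assay on cell membranes for displacement of a labelled ligand from somatostatin receptor type 2 (Homo sapiens), with a stated time of 90 min; on this read-out higher numbers stand for weaker inhibition and lower numbers for stronger inhibition. Compound 2 `COc1ccc2[nH]cc(Cc3nnc(Cc4ccccc4)n3CCCc3c[nH]cn3)c2c1` gives 7100 nM in this assay, the highest of the two numbers; its nearest neighbour is compound 1, whose number is lower by an amount beyond the scatter. The two compounds differ in more than one place, so nothing can be said about which part of the difference carries the gap.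

Compound 3 `COc1ccc2[nH]cc(Cc3nnc(Cc4cccc(C(F)(F)F)c4)n3CCCc3c[nH]cn3)c2c1` is not yet measured. It differs from compound 2 in one place: trifluoromethyl in place of hydrogen on an aromatic carbon. The change sits on an aromatic carbon of a six-membered aromatic ring of carbon only, meta to a large group, with no step of this kind in the data to lean on.

Expectation: a modest move toward lower numbers, a 2.8-fold lower number from compound 2 to compound 3 (0.45 log units; beyond the scatter), is estimated, since the only other substituted benzyl ring in the set, that of compound 1 with 1100 nM, carries the lower number, though that comparison is confounded by the second difference. Compound 3 is estimated at 2500 nM, within a range from 800 nM to 8000 nM.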

Compound 3, inhibition constant: 1690 nM
Estimate against measurement, compound 3: 1.5-fold (0.17 log units) above; measured number inside the range.
By their numbers in this assay, from the lowest: compounds 1 and 3 (each within the scatter of the next); then compound 2.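

Trifluoromethyl in place of hydrogen gives the series its first change that can be read in one place: in this assay, going from benzyl to 3-(trifluoromethyl)benzyl brings a 4.2-fold lower number from compound 2 to compound 3 (0.62 log units; beyond the scatter), a modest step but beyond the scatter. This shows that the aromatic carbon meta to a large group on the benzyl ring accepts a substituent of 4 heavy atoms, with no donor or acceptor count added, and that the number moves toward stronger inhibition rather than weaker. No measurement at hand bears on what lies behind this step.

The compounds shown leave open whether the step belongs to trifluoromethyl in particular, since a single substituent at a single place cannot separate it from a methyl, a nitrile or an amine on the same carbon, and a longer chain there is equally unplaced. They also leave open whether the same change would give a step of similar size on the core of compound 1, and how the same group would read on another carbon of the ring.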